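A few compounds are considered here, and "the series" means these few. Any claim that something is new, unique, unknown or untested is made for them only; others in the source may bear on it.

Compound 3 `COc1ccc(/C=C2/N=C(c3ccccc3)N(c3ccc4oc(-c5ccccc5)cc(=O)c4c3)C2=O)cc1OC` gives 11.1 ug/mL in a functional assay on HeLa cells (Homo sapiens) for inhibition, read by sulforhodamine B assay; a lower number here means a stronger inhibitor, a higher number a weaker inhibitor. For the measured compounds named here, its number sits at the low end of the three measured so far, with compound 2 `O=C1/C(=C\c2ccc(Cl)c(Cl)c2)N=C(c2ccccc2)N1c1ccc2oc(-c3ccccc3)cc(=O)c2c1` at 16 ug/mL and compound 1 `COc1ccc(/C=C2/N=C(c3ccccc3)N(c3ccc4oc(-c5ccccc5)cc(=O)c4c3)C2=O)cc1` at 17.6 ug/mL, but the gaps to both lie within the scatter, so no ranking among the three can be read from these numbers.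

Compound 4 `O=C1/C(=C\c2ccc(O)cc2)N=C(c2ccccc2)N1c1ccc2oc(-c3ccccc3)cc(=O)c2c1` differs from compound 3 by 4-hydroxyphenyl in place of 3,4-dimethoxyphenyl on a double-bonded chain carbon bound to a double-bonded ring carbon. The steps already measured at this same position, a 1.1-fold lower number from compound 1 to compound 2 (0.04 log units; within the scatter) and a 1.4-fold lower number from compound 2 to compound 3 (0.16 log units; within the scatter), together with the added methoxy in a 1.6-fold lower number from compound 1 to compound 3 (0.20 log units; within the scatter), all stayed within the scatter. Exchanging the aryl group on the double-bonded chain carbon has therefore not yet moved this assay beyond the scatter, and the same is expected for compound 4, with an estimated step of a 1.4-fold higher number from compound 3 to compound 4 (0.13 log units; within the scatter) that should not exceed the scatter. Going by the values given here, a 4-hydroxyphenyl at this position has no measured precedent, so the range is kept wide. Compound 4 is estimated at 15 ug/mL in this assay, with a range from 7 ug/mL to 32 ug/mL.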

Compound 4, half-maximal inhibitory concentration: 18.9 ug/mL
Beside the measured number, compound 4's estimate is 1.3-fold (0.10 log units) below it; the range from low to high includes it.
By their numbers in this assay, from the lowest: compounds 3, 2, 1 and 4 (each within the scatter of the next).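

The 4-hydroxyphenyl group carries a hydrogen-bond donor, which the 3,4-dimethoxyphenyl group does not, yet in this assay the exchange gives no step beyond the scatter (a 1.7-fold higher number from compound 3 to compound 4 (0.23 log units; within the scatter)). The same holds against the dichlorinated aryl group (a 1.2-fold higher number from compound 2 to compound 4 (0.07 log units; within the scatter)) and for hydrogen in place of methyl on the aromatic oxygen (a 1.1-fold higher number from compound 1 to compound 4 (0.03 log units; within the scatter)), so this assay does not separate any of the four aryl groups on the double-bonded chain carbon. Nothing available explains this lack of separation.

Still open, from the compounds shown here alone, is whether an amine or a carboxylic acid on this aryl ring, or a longer chain in place of the ring, would give a step beyond the scatter. Also open, going by these compounds, is whether any change to the shared core would do so in this assay.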